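Swapping the aromatic ring: pyridinyl in place of dimethylphenyl

The source may report more compounds than this note shows. Statements on the series, on what has been measured and on what is new or still open speak of the compounds shown alone.

Measured so far:
- compound 1, `CCc1nc2ccccc2n1CCCCOc1ccc(C)c(C)c1`: 14 uM
- compound 2, `CCc1nc2ccc(Cl)cc2n1CCCCOc1ccccc1`: 25 uM

Both compounds were tested in an ADME assay on Vero cells (Chlorocebus sabaeus) for cytotoxicity, read by luminescence, with a stated time of 2 days; a higher number here means that more compound is tolerated, a lower number that less compound is tolerated. In this assay compound 1 gives 14 uM, and compound 2 gives 25 uM; the gap between these two numbers lies within the usual scatter of the measurement, so they cannot be told apart. For the measured compounds named here, no step between measured compounds is available here, so nothing about the effect of any single change has been seen directly.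

The next compound, compound 3, `CCc1nc2ccccc2n1CCCCOc1cccnc1`, differs from compound 1 in one place: pyridin-3-yl in place of 3,4-dimethylphenyl on an oxygen on a saturated carbon. Going by the values given here, with no comparable step measured, the expected step of a 1.8-fold higher number from compound 1 to compound 3 (0.25 log units; within the scatter) is a small one, tending toward more compound being tolerated, but it may well fall within the scatter. On that basis compound 3 is estimated to give 25 uM in this assay, with an expected range from 10 uM to 60 uM.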

Compound 3, half-maximal toxic concentration: > 50 uM
Compound 3 was reported as a limit (the forecaster's own chance of this, stated with the estimate: 20%); middle value at least 2.0-fold (0.30 log units) from the limit.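

Compound 3 gives > 50 uM in this assay, and this value is a limit of the assay, not a number. Putting pyridin-3-yl in place of 3,4-dimethylphenyl gives an at least 3.5-fold higher number from compound 1 to compound 3 (0.55 log units; beyond the scatter), the first single change seen directly among these compounds. It shows that the group on this oxygen can move the tolerated concentration by more than the scatter, something the earlier values alone could not show.

On these data alone, the step swaps two things at once, a ring nitrogen enters and two methyl groups leave, so which of them matters stays open, as does what a pyridin-2-yl or a morpholine would do at this place. How far the tolerated concentration of compound 3 lies past the limit is also unknown: the limit of > 50 uM in this assay, at which 1 of the 3 values shown sits.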